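Two fluorines on the benzyl arm of a nucleoside

A few compounds are considered here, and "the series" means these few. Any claim that something is new, unique, unknown or untested is made for them only; others in the source may bear on it.

Measured compounds:
compound 1, `OC[C@H]1O[C@@H](n2cnc3c(NCc4cccc(F)c4)ncnc32)[C@H](O)[C@@H]1O`: 920 nM
compound 2, `OC[C@H]1O[C@@H](n2cnc3c(NCc4ccc(Cl)cc4)ncnc32)[C@H](O)[C@@H]1O`: 1700 nM

Going by the values given here, in a functional assay on HL-60 cells (Homo sapiens) for antiproliferative activity, with a stated time of 72 h (on this read-out higher numbers stand for weaker inhibition and lower numbers for stronger inhibition), compound 1 gives 920 nM, the lowest of the two numbers so far; its nearest neighbour is compound 2 at 1700 nM, and the step of a 1.8-fold higher number from compound 1 to compound 2 (0.27 log units; within the scatter) stays inside the scatter, so the two cannot be ranked. Compound 3, `OC[C@H]1O[C@@H](n2cnc3c(NCc4ccc(F)cc4F)ncnc32)[C@H](O)[C@@H]1O`, has not yet been measured in this assay. It differs from compound 1 at one place: 2,4-difluorophenyl in place of 3-fluorophenyl on a saturated chain carbon bound to a nitrogen on an aromatic ring. Among the compounds with values here, the only measured step that touches this place is the exchange a 1.8-fold higher number from compound 1 to compound 2 (0.27 log units; within the scatter), in which a different halogenated phenyl group sits on the same saturated chain carbon bound to a nitrogen on an aromatic ring; it produced no shift beyond the scatter. With one neighbour and no step that adds a second fluorine to this ring, the data give no reason to expect a large move in either direction. Compound 3 is therefore expected to give 1000 nM, within 400 nM to 2500 nM. The expected step of a 1.1-fold higher number from compound 1 to compound 3 (0.04 log units; within the scatter) is estimated to lie within the scatter.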

Compound 3, half-maximal inhibitory concentration: 3400 nM
Compound 3: the middle estimate sits 3.4-fold (0.53 log units) below what was measured; the whole stated range lies below it.
By their numbers in this assay, from the lowest: compounds 1, 2 and 3 (each within the scatter of the next, the first and the last beyond it).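

In this assay, going by these compounds alone, the 2,4-difluorophenyl group gives the first step at this place that is clearly beyond the scatter, though only a modest one: a 3.7-fold higher number from compound 1 to compound 3 (0.57 log units; beyond the scatter). The earlier exchange of one halogenated phenyl group for another could not show that the halogen substitution on this ring registers in the read-out at all. The 4-chlorophenyl group, however, cannot be separated from the 2,4-difluorophenyl group, a 2.0-fold higher number from compound 2 to compound 3 (0.30 log units; within the scatter), so the three compounds form no clean ranking, and only the two ends of the series stand apart. No measurement bears on why the number shifts at this place.

Compound 3 differs from compound 1 in both the number and the placing of its fluorines, and the compounds shown cannot tell these two changes apart. They also leave open how this place responds to a ring carrying no halogen, such as one with a methoxy group or a hydroxyl group, or to a longer chain between the ring and the nitrogen.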